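This account rests on a few compounds, and the source may have more. Where it says the series, first, only, none or still open, it means among the compounds named here.

Compound 1 `COc1ccc(-c2csc(N)c2C(=O)OCc2ccccc2)cc1OC` gives 100% in an assay on isolated protein for inhibition of protein kinase C zeta type (Homo sapiens), with stated times of 1 h and 2.5 min, tested at 30 uM; on this read-out higher numbers stand for more inhibition at the one concentration tested (going by the name of the read-out) and lower numbers for less inhibition. Compound 2 `COc1ccc(-c2csc(N)c2C(=O)OCc2ccc(F)cc2)cc1OC` differs from compound 1 by fluoro in place of hydrogen on an aromatic carbon; in this assay compound 2 gives 2%, a step of a number 98 percentage points lower from compound 1 to compound 2 (beyond the scatter). Compound 3 `COc1ccc(-c2csc(N)c2C(=O)OCc2ccccc2)cc1` has a different core, the difference being (hydrogen in place of methoxy on an aromatic carbon); in this assay compound 3 gives 86%, a step of a number 14 percentage points lower from compound 1 to compound 3 (beyond the scatter). Compound 4 `COc1ccc(-c2csc(N)c2C(=O)OCc2ccccc2)c(F)c1`, not yet measured, differs from compound 3 by fluoro in place of hydrogen on an aromatic carbon. This is the same kind of change as from compound 1 to compound 2, though there the fluoro sits para to a large group, whereas here it sits ortho to a large group and meta to a methoxy group. Resting on the step of a number 98 percentage points lower from compound 1 to compound 2 (beyond the scatter), a step of comparable direction, a number 66 percentage points lower from compound 3 to compound 4 (beyond the scatter), is expected for compound 4 in this assay, with the different place leaving the size uncertain. Compound 4 is estimated at 20% in this assay, expected to fall between 0% and 65%.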

Compound 4, a percentage reported as inhibition, at one concentration (the size of the read-out at that concentration, not a potency): 78%
Compound 4: the middle estimate sits 58 percentage points below what was measured, and the stated range ends below it.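

Fluoro in place of hydrogen on an aromatic carbon does not carry over from one core to another in this series as a fixed step in this assay: the same change on two cores in this assay, a number 98 percentage points lower (beyond the scatter) from compound 1 to compound 2 and a number 8 percentage points lower (within the scatter) from compound 3 to compound 4, 90 percentage points apart, beyond the scatter of two such steps. The new step is a number 8 percentage points lower from compound 3 to compound 4 (within the scatter), so fluoro ortho to a large group and meta to a methoxy group leaves the read-out within the scatter. This does not show whether the gap between the steps follows from the core or from the place of the fluoro, since the two pairs differ in both.

The compounds shown leave open how this fluoro place would read on the core of compound 1. They also leave open how a chloro group, a nitrile or an amine would read at that aromatic carbon.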